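Triazole-linked diaryl ureas: aryl swap on the triazole

The source may report more compounds than this note shows. Statements on the series, on what has been measured and on what is new or still open speak of the compounds shown alone.

Compound 1 `O=C(Nc1cccc(OCc2cn(-c3ccccc3)nn2)c1)Nc1ccc(Cl)c(C(F)(F)F)c1` in a toxicity assay on MRC5 cells (Homo sapiens) for inhibition, read by MTT assay, with a stated time of 72 h (on this read-out higher numbers stand for weaker inhibition and lower numbers for stronger inhibition), gives 18400 nM.
Compound 2 `COc1cccc(-n2cc(COc3cccc(NC(=O)Nc4ccc(Cl)c(C(F)(F)F)c4)c3)nn2)c1` in this assay gives 8570 nM.

For the measured compounds named here, compound 2 holds the lowest of the two numbers; the only measured step, a 2.1-fold lower number from compound 1 to compound 2 (0.33 log units; beyond the scatter), separates it from the other compound. Compound 3 `N#Cc1ccccc1-n1cc(COc2cccc(NC(=O)Nc3ccc(Cl)c(C(F)(F)F)c3)c2)nn1` differs from compound 2 by 2-cyanophenyl in place of 3-methoxyphenyl on an aromatic nitrogen. Going by the values given here, no measured step concerns a swap of one aryl for another on that ring nitrogen; the single step, a 2.1-fold lower number from compound 1 to compound 2 (0.33 log units; beyond the scatter), is modest and only shows a methoxy added. The change is therefore expected to give no step beyond the scatter, a 1.2-fold higher number from compound 2 to compound 3 (0.07 log units; within the scatter). Compound 3 is estimated at 10000 nM, within 4000 nM to 25000 nM.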

Compound 3, half-maximal inhibitory concentration: 17500 nM
For compound 3 the middle estimate is 1.8-fold (0.24 log units) below the measured one, within the range that was stated.
By their numbers in this assay, from the lowest: compound 2; then compounds 3 and 1 (each within the scatter of the next).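

Swapping one aryl for another on the aromatic nitrogen does shift the number in this assay: 2-cyanophenyl in place of 3-methoxyphenyl gives a 2.0-fold higher number from compound 2 to compound 3 (0.31 log units; beyond the scatter) as a modest step. The nitrile alone gives a 1.1-fold lower number from compound 1 to compound 3 (0.02 log units; within the scatter) and so leaves the plain phenyl result unchanged within the scatter, which sets only 3-methoxyphenyl apart among these three aryls. No measurement at hand accounts for this difference.

As far as these compounds go, how an amine or a carboxylic acid on this aryl would read remains open, as does whether the methoxy and nitrile results depend on where each group sits on the ring.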